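Swapping the Aryl Substituent: Morpholine Amide to Methylsulfonyl

The source may report more compounds than this note shows. Statements on the series, on what has been measured and on what is new or still open speak of the compounds shown alone.

Three compounds built on one shared core were measured in a functional assay on HT-29 cells (Homo sapiens); a higher number here means that more compound is needed for the effect, a lower number that less compound is needed. Compound 1 `CS(=O)(=O)Nc1ccc(-c2cc(C(=O)N[C@H]3CCCNC3)c(NC(N)=O)s2)cc1` gives 2200 nM. Compound 2 `CN(C)c1ccc(-c2cc(C(=O)N[C@H]3CCCNC3)c(NC(N)=O)s2)cc1` gives 90 nM. Compound 3 `NC(=O)Nc1sc(-c2ccc(C(=O)N3CCOCC3)cc2)cc1C(=O)N[C@H]1CCCNC1` gives 610 nM, which places it second highest of the three numbers, with a 3.6-fold lower number from compound 1 to compound 3 (0.56 log units; beyond the scatter) and a 6.8-fold higher number from compound 2 to compound 3 (0.83 log units; beyond the scatter). The three differ only in one group on an aromatic carbon, and the widest step seen at that position is a 24-fold lower number from compound 1 to compound 2 (1.39 log units; beyond the scatter).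

Compound 4 `CS(=O)(=O)c1ccc(-c2cc(C(=O)N[C@H]3CCCNC3)c(NC(N)=O)s2)cc1` has not yet been measured. It differs from compound 3 as follows: methylsulfonyl in place of (morpholin-4-yl)carbonyl on an aromatic carbon. Among the compounds with values here, no measured compound carries a methylsulfonyl group, so the two steps that touch compound 3 show only how far this position can move, from a modest step to a large one. For compound 4 a modest change in this assay is expected, more likely upward than downward, and a step of the size that separates compound 3 from compound 1 is taken as the guide. The estimate for compound 4 is 1200 nM, with a range from 400 nM to 4000 nM, which means an expected 2.0-fold higher number from compound 3 to compound 4 (0.29 log units; within the scatter).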

Compound 4, half-maximal effective concentration: 200 nM
For compound 4 the middle estimate is 6.0-fold (0.78 log units) above the measured one; measured number outside the range, below it.
By their numbers in this assay, from the lowest: compound 2; then compound 4; then compound 3; then compound 1.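

In this assay methylsulfonyl in place of (morpholin-4-yl)carbonyl gives a 3.1-fold lower number from compound 3 to compound 4 (0.48 log units; beyond the scatter), showing that this position tolerates a group without a ring and with fewer heavy atoms, although the counts of hydrogen-bond donors and acceptors stay the same. The other two comparisons, an 11-fold lower number from compound 1 to compound 4 (1.04 log units; beyond the scatter) and a 2.2-fold higher number from compound 2 to compound 4 (0.35 log units; beyond the scatter), set the order of the numbers from lowest to highest as dimethylamino, methylsulfonyl, (morpholin-4-yl)carbonyl and methanesulfonamido. Nothing available here accounts for this order.

The step from compound 3 to compound 4 removes the ring and changes the heavy-atom count together, so the contribution of each remains unresolved. On these data alone, how a carboxylic acid, a primary amine or an ethylsulfonyl group would fit into this order also remains open.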